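Trifluoromethyl for Fluoro: A Cytotoxicity Pair Compared

This account rests on a few compounds, and the source may have more. Where it says the series, first, only, none or still open, it means among the compounds named here.

Measured compounds:
Compound 1, `Nc1ccc2oc(-c3ccc(F)cc3)cc(=O)c2c1`, 10000 nM
Compound 2, `Nc1ccc2oc(-c3ccc(C(F)(F)F)cc3)cc(=O)c2c1`, 1900 nM
Compound 3, `Nc1ccc2oc(-c3cccc(F)c3)c(O)c(=O)c2c1`, 30000 nM

Three compounds have been run in an ADME assay on THP-1 cells (Homo sapiens) for cytotoxicity, read by flow cytometry and propidium iodide staining, with a stated time of 72 h; on this read-out higher numbers stand for weaker inhibition and lower numbers for stronger inhibition. Compound 1 gives 10000 nM, compound 2 gives 1900 nM, and compound 3 gives 30000 nM. Compound 1 and compound 2 differ in one place: trifluoromethyl in place of fluoro on an aromatic carbon. That change produced a 5.3-fold lower number from compound 1 to compound 2 (0.72 log units; beyond the scatter). Compound 3 stands highest of the three numbers, its nearest neighbour being compound 1 and its furthest compound 2.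

Compound 4, `Nc1ccc2oc(-c3cccc(C(F)(F)F)c3)c(O)c(=O)c2c1`, has not yet been measured. It is related to compound 3 by trifluoromethyl in place of fluoro on an aromatic carbon. Going by the values given here, this is the same kind of change as the one from compound 1 to compound 2, but not the same: in the first pair the group sits para to a large group, in the second pair it sits meta to a large group. The difference between the core of compound 1 and the core of compound 3 is not broken down here.

Among the compounds with values here, compound 4 is expected to fall by about a 4.3-fold lower number from compound 3 to compound 4 (0.63 log units; beyond the scatter) in this assay, a step of roughly the size seen from compound 1 to compound 2, because that step, a 5.3-fold lower number from compound 1 to compound 2 (0.72 log units; beyond the scatter), is the only guide available. The differing place around the group and the different core leave room for a smaller or larger step. The estimate for compound 4 in this assay is 7000 nM, with a range from 2500 nM to 20000 nM.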

Compound 4, half-maximal inhibitory concentration: 2000 nM
The estimate for compound 4 lay 3.5-fold (0.54 log units) above the measured number; measured number outside the range, below it.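

In this assay, trifluoromethyl in place of fluoro gave a 15-fold lower number from compound 3 to compound 4 (1.18 log units; beyond the scatter), so the direction seen on the core of compound 1 also held on the core of compound 3. The size of the step did not carry over, and the change cannot be treated as a fixed increment across these two cores: the same change on two cores in this assay, a 5.3-fold lower number (0.72 log units; beyond the scatter) from compound 1 to compound 2 and a 15-fold lower number (1.18 log units; beyond the scatter) from compound 3 to compound 4, 2.9-fold (0.45 log units) apart, beyond the scatter of two such steps What this does not show is why the two steps differ, since the pairs differ both in their core and in where the group sits, with the group in compound 4 meta to a large group and the group in compound 2 placed differently, and two pairs cannot separate these two differences or support a rule for other cores in the series.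

The compounds shown leave open how much of the gap belongs to the core and how much to the place of the group, a question that would need fluoro and trifluoromethyl at the same place on both cores. They also leave open whether a chloro, methyl or nitrile group at that place would follow the same direction as trifluoromethyl, and how large any such step would be.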